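This account rests on a few compounds, and the source may have more. Where it says the series, first, only, none or still open, it means among the compounds named here.

- Compound 1 `COc1cccc(/C=C2\CCC/C(=C\c3ccccc3Cl)C2=O)c1OC`: 44200 nM
- Compound 2 `COc1cccc(/C=C2\CCC/C(=C\c3ccc(Cl)c(Cl)c3)C2=O)c1OC`: 25500 nM

These two compounds share a core and have been measured in an ADME assay on NHDF cells (Homo sapiens) for cytotoxicity, read by MTT assay, with a stated time of 72 h; a higher number here means a weaker inhibitor, a lower number a stronger inhibitor. Going by the values given here, in this test compound 2 gives 25500 nM, which lies within the usual scatter of the only other measured compound, so the numbers do not rank the pair.

The next compound to be tested is compound 3 `COc1cccc(/C=C2\CCC/C(=C\c3cc(Cl)cc(Cl)c3)C2=O)c1OC`. It has the same atoms as compound 2, joined differently, with 3,5-dichlorophenyl in place of 3,4-dichlorophenyl on a double-bonded chain carbon bound to a double-bonded ring carbon.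

Among the compounds with values here, one measured step bears on this change, because it also alters the chlorinated phenyl group at this place: a 1.7-fold lower number from compound 1 to compound 2 (0.24 log units; within the scatter). Within the data shown here, this single step offers only limited guidance, and no measured compound yet carries the 3,5-dichlorophenyl group. No step beyond the scatter is therefore expected in this assay, and no direction can be predicted with confidence.

The estimate corresponds to an expected 1.1-fold higher number from compound 2 to compound 3 (0.04 log units; within the scatter). The expected value for compound 3 is 28000 nM, within an estimated range of 13000 nM to 55000 nM.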

Compound 3, half-maximal inhibitory concentration: 21600 nM
The estimate for compound 3 lay 1.3-fold (0.11 log units) above the measured number; low and high end bracket the measured number.
By their numbers in this assay, from the lowest: compounds 3, 2 and 1 (each within the scatter of the next, the first and the last beyond it).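

In this assay, the change from 3,4-dichlorophenyl to 3,5-dichlorophenyl on a double-bonded chain carbon bound to a double-bonded ring carbon gives a 1.2-fold lower number from compound 2 to compound 3 (0.07 log units; within the scatter), so these two placements of the chlorines cannot be told apart in this test. Going by these compounds alone, the comparison with the singly chlorinated 2-chlorophenyl group now gives a 2.0-fold lower number from compound 1 to compound 3 (0.31 log units; beyond the scatter); this is the only step among the three compounds that lies beyond the scatter, and it is a modest one, while compound 2 remains within the scatter of both of the others. No accompanying measurement explains why these numbers fall as they do.

As far as these compounds go, all three compounds carry only chlorine on this phenyl ring, so it remains open whether a different kind of group there, such as an amine, a carboxylic acid or a trifluoromethyl group, would shift the number by more than the scatter. The numbers also come from a single cell test, and they leave open how these compounds would behave in any other test.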